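Cyano in place of methyl in compound 2

This account rests on a few compounds, and the source may have more. Where it says the series, first, only, none or still open, it means among the compounds named here.

Measured in a physicochemical assay for solubility, in phosphate buffer, at pH 7.4; on this read-out lower numbers stand for lower solubility and higher numbers for higher solubility:
- compound 1 `N#CC1CCN(c2nccnc2OC2CN(c3ccc4ccccc4n3)C2)CC1`: 66000 nM
- compound 2 `Cc1ccc(-c2nccnc2OC2CN(c3ccc4ccccc4n3)C2)cc1`: < 1000 nM

Compound 2 reads < 1000 nM, which is only a limit of the assay and not a number; its place is the limit of < 1000 nM in this assay, at which 1 of the 2 values shown sits.

Compound 3 `N#Cc1ccc(-c2nccnc2OC2CN(c3ccc4ccccc4n3)C2)cc1` differs from compound 2 by cyano in place of methyl on an aromatic carbon, with cyano in place of methyl on an aromatic carbon, para to a large group.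

For the measured compounds named here, the one measured step is an at least 66-fold lower number from compound 1 to compound 2 (1.81 log units; beyond the scatter), a large step that brought in 4-methylphenyl in place of 4-cyanopiperidin-1-yl. That is a different change from the present one, and it ends at a limit, so it sets no size here. Compound 3 keeps the six-membered aromatic ring of carbon only, so a return towards compound 1 is not expected. The expected change is small, a number no lower from compound 2 to compound 3 (the limit leaves the size open), with no step beyond the scatter and no firm direction. For compound 3 the estimated value in this assay is 1000 nM, with an expected range of 300 nM to 5000 nM.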

Compound 3, solubility: < 1000 nM
Compound 3: no number, only a limit; the forecaster's own chance of this, stated with the estimate: 55%; the middle value lies on the limit itself.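

In this assay compound 3 gives < 1000 nM, which is a limit of the assay and not a number. Putting 4-cyanophenyl in place of 4-cyanopiperidin-1-yl gives an at least 66-fold lower number from compound 1 to compound 3 (1.81 log units; beyond the scatter), so the large step is not tied to the methyl group of compound 2. Cyano in place of methyl on this aromatic carbon, para to a large group, leaves compound 3 at the same limit as compound 2, and the step between the two cannot be read: the limit of < 1000 nM in this assay, at which 2 of the 3 values shown sit.

From the compounds shown here alone, what number compound 2 and compound 3 would carry stays open, so methyl and cyano cannot be ranked here. Also open, going by these compounds, is whether an amine or a carboxylic acid on the same aromatic carbon would bring the read-out off the limit.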